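A few compounds are considered here, and "the series" means these few. Any claim that something is new, unique, unknown or untested is made for them only; others in the source may bear on it.

Working notes on the series sharing the core of compound 1 `Cc1cccc2sc(NC(=O)CCN3CCN(CCN(C)C)CC3)nc12`. In an assay on membranes from brain for displacement of a labelled ligand from Sigma non-opioid intracellular receptor 1 (Cavia porcellus), read by scintillation counting, with a stated time of 120 min (a lower number here means a stronger inhibitor, a higher number a weaker inhibitor), compound 1 gives 1000 nM. Compound 2 `Cc1cccc2sc(NC(=O)CCN3CCN(CC4CCCCC4)CC3)nc12` gives 35 nM in this assay, and compound 3 `Cc1cccc2sc(NC(=O)CCN3CCN(c4ccncc4)CC3)nc12` gives 9600 nM. Compound 3 stands highest of the three numbers: the step of a 9.6-fold higher number from compound 1 to compound 3 (0.98 log units; beyond the scatter) and the step of a 270-fold higher number from compound 2 to compound 3 (2.44 log units; beyond the scatter) both lie beyond the scatter, so compound 3 is the weakest inhibitor measured so far, and the step of a 29-fold lower number from compound 1 to compound 2 (1.46 log units; beyond the scatter) places compound 2 at the strong end.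

Compound 4 `Cc1cccc2sc(NC(=O)CCN3CCN(c4ncccn4)CC3)nc12` differs from compound 3 only at the ring nitrogen that carries the aromatic group: pyrimidin-2-yl in place of pyridin-4-yl on an amine nitrogen in a ring. For the measured compounds named here, no measured step swaps one six-membered aromatic ring for another at this place; the steps into compound 3 come from saturated or chain groups and both point to aromatic groups giving higher numbers. The change from compound 3 to compound 4 is therefore expected to be small, a step of a 1.0-fold higher number from compound 3 to compound 4 (0.02 log units; within the scatter), within or close to the scatter. The expected value for compound 4 in this assay is 10000 nM, with a range from 3000 nM to 30000 nM.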

Compound 4, inhibition constant: 505 nM
The estimate for compound 4 lay 20-fold (1.30 log units) above the measured number; measured number below the stated range.
By their numbers in this assay, from the lowest: compound 2; then compounds 4 and 1 (each within the scatter of the next); then compound 3.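

In this assay the identity of the six-membered aromatic ring on the amine nitrogen matters: with pyrimidin-2-yl in place of pyridin-4-yl, the series shows a 19-fold lower number from compound 3 to compound 4 (1.28 log units; beyond the scatter) for a change from 1 to 2 hetero atoms in that ring. The high number of compound 3 therefore cannot be read as a general result for aromatic groups at this place, since a 2.0-fold lower number from compound 1 to compound 4 (0.30 log units; within the scatter) leaves the aromatic compound 4 within the scatter of the chain-bearing compound 1. The cyclohexylmethyl group still stands apart from pyrimidin-2-yl, with a 14-fold higher number from compound 2 to compound 4 (1.16 log units; beyond the scatter) at this nitrogen.

No supporting data bear on the origin of these differences. Open, on these data alone, is whether the step follows the number of ring nitrogens or their placement, which phenyl or pyridin-2-yl on the same nitrogen would help separate.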